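This account rests on a few compounds, and the source may have more. Where it says the series, first, only, none or still open, it means among the compounds named here.

Compound 1 `CC1(C)[C@H]2CC[C@]1(C)N(Cc1cn(-c3cccc(F)c3)nn1)C(=O)C2` and compound 2 `CC1(C)[C@H]2CC[C@]1(C)N(Cc1cn(-c3ccccc3Cl)nn1)C(=O)C2` share one core and differ only in the aryl group on the aromatic nitrogen. In a functional assay on LoVo cells (Homo sapiens) for inhibition, read by MTT assay, with a stated time of 24 h (on this read-out lower numbers stand for stronger inhibition and higher numbers for weaker inhibition), compound 1 gives 90 nM, and compound 2 gives 190 nM. For the measured compounds named here, the one step measured so far, a 2.1-fold higher number from compound 1 to compound 2 (0.32 log units; beyond the scatter), places compound 2 at the highest of the two numbers seen in this assay, with compound 1 as its nearest neighbour.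

Compound 3 `CC1(C)[C@H]2CC[C@]1(C)N(Cc1cn(-c3ccc(Br)cc3)nn1)C(=O)C2` is the next member: 4-bromophenyl in place of 2-chlorophenyl on an aromatic nitrogen. Going by the values given here, no step between a 2-chlorophenyl and a 4-bromophenyl has been measured here; the only step that bears on it, a 2.1-fold higher number from compound 1 to compound 2 (0.32 log units; beyond the scatter), shows that exchanging one halogenated phenyl for another on this nitrogen moved this assay by a modest amount. A similar modest step is therefore expected, with no direction firmly indicated. Compound 3 is estimated at 130 nM in this assay, within 50 nM to 350 nM, which means a step of a 1.5-fold lower number from compound 2 to compound 3 (0.16 log units; within the scatter) is expected.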

Compound 3, half-maximal inhibitory concentration: 60 nM
Estimate against measurement, compound 3: 2.2-fold (0.34 log units) above; measured number inside the range.
By their numbers in this assay, from the lowest: compounds 3 and 1 (each within the scatter of the next); then compound 2.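

For the compounds shown here, with a 3.2-fold lower number from compound 2 to compound 3 (0.50 log units; beyond the scatter) in this assay, compound 2 now stands apart from both other members, and its 2-chlorophenyl is the only aryl group here whose steps to the others all lie beyond the scatter. The second new comparison, a 1.5-fold lower number from compound 1 to compound 3 (0.18 log units; within the scatter), does not separate 4-bromophenyl from 3-fluorophenyl, although these two groups differ in both the halogen and its place on the phenyl ring. Nothing available on these compounds accounts for compound 2 standing apart.

Halogen and ring placement change together in all three compounds, so their contributions stay unresolved; a 4-chlorophenyl would pair the halogen of compound 2 with the placement of compound 3. Also open, going by these compounds, is how a plain phenyl, or a phenyl carrying an amine or a carboxylic acid, would behave on this nitrogen.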